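A few compounds are considered here, and "the series" means these few. Any claim that something is new, unique, unknown or untested is made for them only; others in the source may bear on it.

Measured so far:
compound 1 `COc1ccc2c(c1)[n+]([O-])nc(NCOCc1ccccc1)[n+]2[O-]` gives 2400 nM in a functional assay on KB cells (Homo sapiens) for cytotoxicity, read by MTT assay, with a stated time of 72 h; on this read-out higher numbers stand for weaker inhibition and lower numbers for stronger inhibition;
compound 2 `[O-][n+]1nc(NCOCc2ccccc2)[n+]([O-])c2ccccc21` gives 5720 nM;
compound 3 `CC(OCNc1n[n+]([O-])c2ccccc2[n+]1[O-])c1ccccc1` gives 2510 nM.

Compound 2 stands highest of the three, and both other compounds lie beyond the scatter below it: a 2.4-fold higher number from compound 1 to compound 2 (0.38 log units; beyond the scatter), and a 2.3-fold lower number from compound 2 to compound 3 (0.36 log units; beyond the scatter). Compound 4 `CC(C)CCOCNc1n[n+]([O-])c2ccccc2[n+]1[O-]` differs from compound 2 by isobutyl in place of phenyl on a saturated chain carbon bound to an oxygen on a saturated carbon. Neither measured step touches this part of the molecule: one concerns the methoxy on an aromatic carbon, the other a methyl on the saturated chain carbon, and both were modest. For the measured compounds named here, with no step showing what replacing the phenyl does, compound 4 is expected to move only a little, a 1.1-fold lower number from compound 2 to compound 4 (0.06 log units; within the scatter), perhaps not beyond the scatter in this assay. Compound 4 is therefore estimated at 5000 nM, in the range 2000 nM to 13000 nM.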

Compound 4, half-maximal inhibitory concentration: 3040 nM
Beside the measured number, compound 4's estimate is 1.6-fold (0.22 log units) above it; low and high end bracket the measured number.
By their numbers in this assay, from the lowest: compounds 1, 3, 4 and 2 (each within the scatter of the next, the first and the last beyond it).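

In this assay the phenyl proves dispensable at this place: isobutyl in place of phenyl on a saturated chain carbon bound to an oxygen on a saturated carbon gives a 1.9-fold lower number from compound 2 to compound 4 (0.27 log units; within the scatter). An open chain without a ring thus serves here as well as the aromatic ring does. Nothing available explains this result. The compounds shown leave open whether an amine, a carboxylic acid or a longer chain at this place would behave the same way. They also leave open whether the methoxy of compound 1 would shift the number on the isobutyl series.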